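Difluorophenyl Amide Tested for Liver Cell Toxicity

The source may hold more compounds than are shown below. What is called first, only, known or untested is meant among the compounds shown, and "the series" means these compounds.

Three compounds sharing one core have been examined in an ADME assay on HepG2 2.2.15 cells (Homo sapiens) for cytotoxicity; a lower number here means that less compound is tolerated, a higher number that more compound is tolerated. Compound 1 `O=C(Nc1ncc(C(Oc2ccc3cc(Br)ccc3c2)c2ccc(Cl)cc2)s1)c1cccs1` gives "not toxic" (no number reported) in this assay. Compound 2 `Clc1ccc(C(Oc2ccc3cc(Br)ccc3c2)c2cnc(NCC3CCCCC3)s2)cc1` likewise gives "not toxic" (no number reported) in this assay. Compound 3 `COc1ccc(C(=O)Nc2ncc(C(Oc3ccc4cc(Br)ccc4c3)c3ccc(Cl)cc3)s2)cc1` is the only one with a reported figure, and that figure is a limit of the assay rather than a number: compound 3 gives > 50000 nM in this assay. Compound 3 therefore stands at the top edge of what was measured, as recorded in the limit of > 50000 nM in this assay, at which 1 of the 3 values shown sits, with the other two entries offering no number to compare against it.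

Compound 4 `O=C(Nc1ncc(C(Oc2ccc3cc(Br)ccc3c2)c2ccc(Cl)cc2)s1)c1ccc(F)cc1F` has not yet been measured in this assay. It differs from compound 3 in one place: 2,4-difluorophenyl in place of 4-methoxyphenyl on a carbonyl carbon. The amide, the shared core and the remainder of the molecule are unchanged.

Going by the values given here, no step between two measured compounds is available here to suggest how this assay responds to such a change. Since compound 3 sits at a limit and compounds 1 and 2 are both recorded as tolerated, the expectation for compound 4 is a step of a number no higher from compound 3 to compound 4 (the limit leaves the size open), that is, none beyond the usual scatter. Compound 4 is accordingly estimated to give 50000 nM in this assay, with a range from 25000 nM to 100000 nM, most likely reported again as a limit.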

Compound 4, half-maximal cytotoxic concentration: "not toxic" (no number reported)
No number was reported for compound 4, so the estimate cannot be set against anything.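

Going by these compounds alone, compound 4 is recorded as "not toxic" without a number and compound 3 carries only a limit, so no step between them can be read. The compounds shown leave open how much of any of them is tolerated, and whether 2,4-difluorophenyl and 4-methoxyphenyl differ at all in this assay.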